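Exchanging acetyl for dimethylamino on an aryl-pyrazole series

The compounds below may be only part of what the source reports. "The series", "measured", "known", "first", "only" and "open" are said of these compounds alone.

Compound 1 `COc1cc(C)cc(-c2c(-c3ccnc(-c4ccc(C(C)=O)cc4)c3)cnn2CC#N)c1` was tested in a functional assay on NCI/ADR-RES cells (Homo sapiens) for inhibition, read by sulforhodamine B assay, with a stated time of 48 h; on this read-out lower numbers stand for higher toxicity in this test and higher numbers for lower toxicity in this test. In this assay compound 1 gives only a limit, > 100000 nM, not a number. Compound 2 `COc1cc(C)cc(-c2nn(CC#N)cc2-c2ccc(-c3cccc(C(C)=O)c3)nc2)c1` likewise reaches only a limit in this assay, > 100000 nM. Compound 3 `Cc1cc(O)cc(-c2nn(CC#N)cc2-c2ccnc(-c3ccc(N(C)C)cc3)c2)c1` also gives only a limit in this assay, > 100000 nM. Among the compounds with values here, compound 1 thus stands at the limit of > 100000 nM in this assay, at which 3 of the 3 values shown sit, with no measured step from which its position could be judged further. Compound 4 `COc1cc(C)cc(-c2c(-c3ccnc(-c4ccc(N(C)C)cc4)c3)cnn2CC#N)c1` differs from compound 1 by dimethylamino in place of acetyl on an aromatic carbon. Within the data shown here, no step between measured compounds is known, so a change of a step that the limit leaves unreadable from compound 1 to compound 4 is expected, nothing beyond the scatter. Compound 4 is therefore expected to give about 150000 nM in this assay, with a range from 50000 nM to 500000 nM, most likely again as a limit.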

Compound 4, concentration lethal to 50% of the cells: > 100000 nM
Compound 4: only a limit was reported (the forecaster's own chance of this, stated with the estimate: 85%); the middle value is on the limit's open side.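

Compound 1 and compound 4 both give only a limit, so no step can be read for dimethylamino in place of acetyl. The compounds shown leave open whether this exchange changes toxicity at all.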